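Swapping a Ring Substituent in a Mouse Activation Assay

A few compounds are considered here, and "the series" means these few. Any claim that something is new, unique, unknown or untested is made for them only; others in the source may bear on it.

Measured so far:
compound 1 `O=C1CCC2(c3ccc(F)cc3)OCCCN12` – 75 mg/kg
compound 2 `O=C1CCC2(c3ccccc3)OCCCN12` – 37.5 mg/kg

Both compounds were tested in a functional assay on the whole organism (Central nervous system) for activation, with Mus musculus as the target; on this read-out lower numbers stand for an effect already at smaller amounts and higher numbers for an effect only at larger amounts of compound. Compound 2 stands at the lower of the two numbers, and its nearest neighbour is compound 1; the step of a 2.0-fold lower number from compound 1 to compound 2 (0.30 log units; within the scatter) lies within the scatter, so the two numbers cannot be told apart with confidence.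

Compound 3 `Cc1ccc(C23CCC(=O)N2CCCO3)cc1` has not yet been measured. It differs from compound 2 in a single place: methyl in place of hydrogen on an aromatic carbon. The group sits on an aromatic carbon of a six-membered aromatic ring of carbon only, para to a large group, the same place where compound 1 carries fluoro and compound 2 carries hydrogen.

For the measured compounds named here, only one measured step bears on this change, namely a 2.0-fold lower number from compound 1 to compound 2 (0.30 log units; within the scatter), and it stayed within the scatter. A small group exchanged at that place therefore gives no reason to expect a step beyond the scatter in this assay for compound 3. Compound 3 is estimated at 45 mg/kg, with a range from 22 mg/kg to 90 mg/kg. This estimate means an expected step of a 1.2-fold higher number from compound 2 to compound 3 (0.08 log units; within the scatter).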

Compound 3, dose for half-maximal effect: < 50 mg/kg
Compound 3: only a limit was reported (the forecaster's own chance of this, stated with the estimate: 5%); the middle value does not contradict the limit.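

In this assay, for the compounds shown here, compound 3 carries a limit rather than a number, < 50 mg/kg, so this is the first look at a carbon group at this place on the aromatic ring, where the earlier compounds held only fluoro or hydrogen. Exchanging fluoro for methyl gives an at least 1.5-fold lower number from compound 1 to compound 3 (0.17 log units; that floor lies within the scatter); only the floor of this step is known, so the true step may be larger, but the result does not show that it leaves the scatter. The step between hydrogen and methyl cannot be read, because the result for compound 3 is not an exact number: the limit of < 50 mg/kg in this assay, at which 1 of the 3 values shown sits.

So the three compounds show that methyl at this place still gives an effect in this whole-animal read-out, but they do not place methyl relative to hydrogen, and no order among the three small groups can be drawn. As far as these compounds go, how the read-out would respond to a group of another kind at the same place, such as an amine, a carboxylic acid or a longer chain, remains open.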